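A few compounds are considered here, and "the series" means these few. Any claim that something is new, unique, unknown or untested is made for them only; others in the source may bear on it.

Measured in a functional assay on A20 cells (Mus musculus) for inhibition, with stated times of 1 h, 16 h and 24 h (on this read-out higher numbers stand for weaker inhibition and lower numbers for stronger inhibition), so far:
compound 1 `N#CC1(NC(=O)[C@@H]2C[C@@H](S(=O)(=O)c3ccccc3)C[C@H]2C(=O)N2CCCCC2)CC1` gives 5 nM
compound 2 `N#CC1(NC(=O)[C@@H]2C[C@@H](S(=O)(=O)c3ccccc3)C[C@H]2C(=O)Nc2ccc(F)cc2)CC1` gives 391 nM
compound 3 `N#CC1(NC(=O)[C@@H]2C[C@@H](S(=O)(=O)c3ccccc3)C[C@H]2C(=O)N2CCCC2)CC1` gives 29 nM

Compound 3 holds the second highest of the three numbers, with compound 1 lower and compound 2 higher. Still unmeasured is compound 4 `CN(C)C(=O)[C@@H]1C[C@H](S(=O)(=O)c2ccccc2)C[C@H]1C(=O)NC1(C#N)CC1`, which differs from compound 3 as follows: dimethylamino in place of pyrrolidin-1-yl on a carbonyl carbon in short, dimethylamino in place of pyrrolidin-1-yl on a carbonyl carbon. Going by the values given here, the nearest precedent is the exchange of piperidin-1-yl for pyrrolidin-1-yl (a 5.8-fold higher number from compound 1 to compound 3 (0.76 log units; beyond the scatter)) which is modest, beyond the scatter, and towards weaker inhibition. The steps involving (4-fluorophenyl)amino (a 78-fold higher number from compound 1 to compound 2 (1.89 log units; beyond the scatter) and a 13-fold lower number from compound 2 to compound 3 (1.13 log units; beyond the scatter)) are both large and show that the group on this carbonyl carbon can move the number strongly, but they bear less directly on the present change. Among the compounds with values here, no measured compound lacks a ring in this group, so the step is an extrapolation and the range must stay wide. A modest step towards a higher number is expected in this assay (estimated as a 2.1-fold higher number from compound 3 to compound 4 (0.32 log units; beyond the scatter)) though a step within the scatter would not be surprising. The estimate for compound 4 is 60 nM with an expected range of 15 nM to 240 nM on this read-out.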

Compound 4, half-maximal inhibitory concentration: 91 nM
Compound 4: middle estimate off by 1.5-fold (0.18 log units), on the low side, and the stated range covers the measured number.
By their numbers in this assay, from the lowest: compound 1; then compound 3; then compound 4; then compound 2.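

In this assay, going by these compounds alone, the first ring-free group on this carbonyl carbon gives a 3.1-fold higher number from compound 3 to compound 4 (0.50 log units; beyond the scatter) and so extends the upward trend seen on leaving piperidin-1-yl: opening the ring of pyrrolidin-1-yl to dimethylamino weakens inhibition further, yet by a step that stays modest. The three groups without an amide hydrogen now form an ordered set, piperidin-1-yl, then pyrrolidin-1-yl, then dimethylamino, and the full span of that set is large, with an 18-fold higher number from compound 1 to compound 4 (1.26 log units; beyond the scatter) as its measure, while compound 2 stands outside the order, since the change to the ring-free group still gives a 4.3-fold lower number from compound 2 to compound 4 (0.63 log units; beyond the scatter) and (4-fluorophenyl)amino remains the weakest of the four. Nothing shown gives a measured basis for this order.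

As far as these compounds go, whether the trend continues past piperidin-1-yl remains open, as azepan-1-yl or morpholin-4-yl would test a larger ring and a ring with a second hetero atom. Diethylamino would help to separate the presence of a ring from the number of carbons in the group, and methylamino would show whether the gap to compound 2 follows the amide hydrogen or the fluorophenyl ring.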